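A few compounds are considered here, and "the series" means these few. Any claim that something is new, unique, unknown or untested is made for them only; others in the source may bear on it.

Three compounds have been measured:
compound 1, `COc1cc(CNC(=O)/C=C/c2ccccc2OCc2nc(C)c(C)nc2C)ccc1O`, gives 12000 nM in a functional assay on SH-SY5Y cells (Homo sapiens) for cytotoxicity, read by MTT assay, with stated times of 24 h and 4 h; a lower number here means that less compound is needed, a higher number that more compound is needed for the effect;
compound 2, `COc1cc(CNC(=O)/C=C/c2ccccc2OCc2nc(C)c(C)nc2C)ccc1OCc1nc(C)c(C)nc1C`, gives 6280 nM in this assay;
compound 3, `COc1cc(CNC(=O)/C=C/c2ccc(O)cc2)ccc1OCc1nc(C)c(C)nc1C`, gives 3740 nM in this assay.

Compound 2 differs from compound 1 by (3,5,6-trimethylpyrazin-2-yl)methyl in place of hydrogen on an oxygen on an aromatic ring, and that change gave a 1.9-fold lower number from compound 1 to compound 2 (0.28 log units; within the scatter). Compound 3 and compound 1 are built from the same atoms joined differently; how the two cores differ is not broken down here. Compound 3 and compound 2 give numbers within the usual scatter of each other, while compound 3 and compound 1 lie beyond it.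

Compound 4, `COc1cc(CNC(=O)/C=C/c2ccc(OCc3nc(C)c(C)nc3C)cc2)ccc1OCc1nc(C)c(C)nc1C`, has not yet been measured. It differs from compound 3 by (3,5,6-trimethylpyrazin-2-yl)methyl in place of hydrogen on an oxygen on an aromatic ring. For the measured compounds named here, this is the same change as the one from compound 1 to compound 2, made at the same kind of place. Because a 1.9-fold lower number from compound 1 to compound 2 (0.28 log units; within the scatter) was small, a step of similar size is expected here, namely a 1.5-fold lower number from compound 3 to compound 4 (0.17 log units; within the scatter). Compound 4 is therefore expected to give about 2500 nM in this assay, most likely between 1200 nM and 5500 nM.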

Compound 4, half-maximal effective concentration: 7770 nM
Estimate against measurement, compound 4: 3.1-fold (0.49 log units) below; the whole stated range lies below it.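

Replacing the hydrogen with (3,5,6-trimethylpyrazin-2-yl)methyl on an oxygen on an aromatic ring gave a 2.1-fold higher number from compound 3 to compound 4 (0.32 log units; beyond the scatter) in this assay. Set side by side, the two measured steps for this change do not agree: the same change on two cores in this assay, a 1.9-fold lower number (0.28 log units; within the scatter) from compound 1 to compound 2 and a 2.1-fold higher number (0.32 log units; beyond the scatter) from compound 3 to compound 4, 4.0-fold (0.60 log units) apart, beyond the scatter of two such steps. This shows that, in this series, the step seen on one core cannot simply be carried over to another, so the effect of adding this group has to be measured on each core; it does not show why the two cores respond differently, and two cores are too few to give a rule for a third.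

The compounds shown leave open whether this disagreement belongs to the (3,5,6-trimethylpyrazin-2-yl)methyl group itself or would also appear with a plain methyl group, or with a chain ending in an amine or a carboxylic acid, on the same oxygen. They also leave open how the same change would behave on any further core.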